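Compound 4: Hydrogen in Place of Methyl

This account rests on a few compounds, and the source may have more. Where it says the series, first, only, none or still open, it means among the compounds named here.

In a functional assay on the whole organism with Rattus norvegicus as the target (on this read-out lower numbers stand for an effect already at smaller amounts and higher numbers for an effect only at larger amounts of compound), compound 2 (`CNC(=O)/C=C1\CCc2cc(F)c(F)cc21`) gives 11 mg/kg, level with compound 3 (`O=C(/C=C1\CCc2ccc(F)cc21)NC1CCCC1`) at 11 mg/kg and within the scatter of compound 1 (`CN(C)C(=O)/C=C1\CCc2ccc(F)cc21`) at 12 mg/kg. Compound 4 (`NC(=O)/C=C1\CCc2cc(F)c(F)cc21`) has hydrogen in place of methyl on an amide-type nitrogen. Among the compounds with values here, one measured step bears on this nitrogen: a 1.1-fold lower number from compound 1 to compound 3 (0.04 log units; within the scatter), with cyclopentylamino in place of dimethylamino, stays within the scatter. Within the data shown here, no measured compound carries the amino group of compound 4, so that evidence is indirect. The expected step, a 1.1-fold higher number from compound 2 to compound 4 (0.04 log units; within the scatter), is therefore none beyond the scatter, in either direction. Compound 4 is estimated at 12 mg/kg, with an expected range from 5 mg/kg to 28 mg/kg.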

Compound 4, dose for half-maximal effect: 17 mg/kg
For compound 4 the middle estimate is 1.4-fold (0.15 log units) below the measured one; the measured number falls inside the stated range.
By their numbers in this assay, from the lowest: compounds 2, 3, 1 and 4 (each within the scatter of the next).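

In this assay, within the data shown here, the exchange of methylcarbamoyl for carbamoyl gives the first direct reading at this nitrogen: a 1.5-fold higher number from compound 2 to compound 4 (0.19 log units; within the scatter). The earlier step had only swapped one carbon-bearing amino group for another, whereas this one shows that removing the last carbon substituent from the nitrogen still leaves the result inside the scatter. Nothing measured here offers an explanation for this result. From the compounds shown here alone, whether a longer chain or a hydroxyl on this nitrogen would also stay within the scatter remains open. So does the outcome of a carboxylic acid in place of the carbamoyl group.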